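The source may report more compounds than this note shows. Statements on the series, on what has been measured and on what is new or still open speak of the compounds shown alone.

Compound 1 `O=C(Nc1cccc(-n2cc(-c3ccncc3)c(-c3cc(O)cc(Cl)c3)n2)c1)Nc1ccc(Cl)c(C(F)(F)F)c1` carries a hydroxyl on one aryl ring and a diaryl urea; in a functional assay on SN12C cells (Homo sapiens) for inhibition, read by sulforhodamine B assay, with a stated time of 48 h, tested at 1 uM (a lower number here means a stronger effect, a higher number a weaker effect of the compound at the concentration tested), compound 1 gives 97%. Compound 2 `COc1cc(Cl)cc(-c2nn(-c3cccc(NC(=O)Nc4ccc(Cl)c(C(F)(F)F)c4)c3)cc2-c2ccncc2)c1` differs from it only by methyl in place of hydrogen on an oxygen on an aromatic ring, and in this assay compound 2 gives 63%. The step is a number 34 percentage points lower from compound 1 to compound 2 (beyond the scatter). Compound 2 therefore stands at the lower of the two numbers measured, and its nearest neighbour, compound 1, lies beyond the scatter above it.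

Compound 3 `COc1cc(Cl)cc(-c2nn(-c3cccc(NC(=O)c4cccc(C(F)(F)F)c4)c3)cc2-c2ccncc2)c1` is not yet measured in this assay. The change from compound 2 is 3-(trifluoromethyl)phenyl in place of (4-chloro-3-(trifluoromethyl)phenyl)amino on a carbonyl carbon. Going by the values given here, no measured step touches this part of the molecule: the only step in hand, a number 34 percentage points lower from compound 1 to compound 2 (beyond the scatter), concerns the oxygen substituent on the far ring and says nothing about the urea-to-amide exchange or the loss of the chlorine. The direction of the step is thus open; the expectation rests on compound 2 alone, with a wide range and a modest move toward a weaker read-out, estimated as a number 15 percentage points higher from compound 2 to compound 3 (beyond the scatter). For compound 3 the estimate in this assay is 78%, between 52% and 102%.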

Compound 3, a percentage reported as activity, at one concentration (the size of the read-out at that concentration, not a potency): 58%
Compound 3: middle estimate off by 20 percentage points, on the high side; the range from low to high includes it.
By their numbers in this assay, from the lowest: compounds 3 and 2 (each within the scatter of the next); then compound 1.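

Going by these compounds alone, at the carbonyl carbon, 3-(trifluoromethyl)phenyl in place of (4-chloro-3-(trifluoromethyl)phenyl)amino gives a number 5 percentage points lower from compound 2 to compound 3 (within the scatter) in this assay, the first reading at this end of the molecule, as the earlier step concerned only the oxygen substituent on the far ring. In this pair, the read-out at the tested concentration therefore does not depend on keeping the urea: the amide of compound 3 and the urea of compound 2 cannot be told apart, although the entering group has no hydrogen-bond donor and no chlorine. The data offer no measured basis for explaining this result.

From the compounds shown here alone, the exchange removes the amino nitrogen and the chlorine in a single step, so the separate contribution of each remains open, as does whether the hydroxyl of compound 1 would give a similar step when placed on the amide of compound 3. Also open, going by these compounds, is how the read-out would respond to a carboxylic acid or a dimethylamino group in place of the trifluoromethyl on the 3-(trifluoromethyl)phenyl group.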